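This account rests on a few compounds, and the source may have more. Where it says the series, first, only, none or still open, it means among the compounds named here.

Measured so far in a functional assay on A549 cells (Homo sapiens) for cytotoxicity, read by MTT assay, with a stated time of 48 h; a lower number here means a stronger inhibitor, a higher number a weaker inhibitor:
- compound 1 `C=C1C(=O)O[C@H]2CC3=C[C@H](C/C(C)=C/[C@@H](OC(=O)CCCCBr)[C@H]12)OC3=O`: > 10000 nM
- compound 2 `C=C1C(=O)O[C@H]2CC3=C[C@H](C/C(C)=C/[C@@H](OC(=O)CCl)[C@H]12)OC3=O`: > 10000 nM

Compound 2 gives > 10000 nM, which is a limit of the assay and not a number. Compound 1 also gives only a limit, > 10000 nM. Among the compounds with values here, the series so far therefore offers a single reference point: the limit of > 10000 nM in this assay, at which 2 of the 2 values shown sit.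

The next change leads to compound 3 `C=C1C(=O)O[C@H]2CC3=C[C@H](C/C(C)=C/[C@@H](OC(=O)CC4CCCCC4)[C@H]12)OC3=O`, with cyclohexyl in place of chloro on a saturated chain carbon bound to a carbonyl carbon. Within the data shown here, the one measured step at this place, a step that the two limits leave unreadable from compound 1 to compound 2, gives no size and no direction. Neither enters the expectation for this assay, so compound 3 is expected to stay near that limit, quite possibly reported only as a limit itself. The expected step is a step that the limit leaves unreadable from compound 2 to compound 3. For compound 3 the estimate is 15000 nM, with an expected range of 6000 nM to 40000 nM.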

Compound 3, half-maximal inhibitory concentration: 6900 nM
For compound 3 the middle estimate is 2.2-fold (0.34 log units) above the measured one; the range from low to high includes it.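

In this assay, within the data shown here, compound 3 gives the first value at this position, on a saturated chain carbon bound to a carbonyl carbon, that is a number and not a limit. On these data alone, with cyclohexyl at this place, the change from chloro reads as an at least 1.4-fold lower number from compound 2 to compound 3 (0.16 log units; that floor lies within the scatter), and the change from 3-bromopropyl reads as an at least 1.4-fold lower number from compound 1 to compound 3 (0.16 log units; that floor lies within the scatter); each is only a floor, so the true size of both steps remains unknown. The series still has one shared reference point: the limit of > 10000 nM in this assay, at which 2 of the 3 values shown sit.

The step from compound 1 to compound 2 cannot be read, and the compounds shown give no exact size for either cyclohexyl step. Also open, as far as these compounds go, is whether a phenyl ring, a longer unbranched chain or an amine at this place would give a number in this assay, and how that number would compare with compound 3.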